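From Methyl to Ethoxy on Compound 2

A few compounds are considered here, and "the series" means these few. Any claim that something is new, unique, unknown or untested is made for them only; others in the source may bear on it.

Of the compounds shown here, two sharing one core have been measured so far. In a functional assay on HeLa cells (Homo sapiens) for antiproliferative activity, read by MTT assay, with a stated time of 72 h (on this read-out higher numbers stand for weaker inhibition and lower numbers for stronger inhibition), compound 1 `COc1ccc(-c2c(C(=O)c3cc(OC)c(OC)c(OC)c3)sc3ccccc23)cc1` gives 4200 nM and compound 2 `COc1cc(C(=O)c2sc3ccccc3c2Nc2ccc(C)cc2)cc(OC)c1OC` gives 3500 nM. Compound 2 has the lower of just these two numbers, but they lie within the scatter of each other, so the pair cannot be ranked.

The next structure is compound 3 `CCOc1ccc(Nc2c(C(=O)c3cc(OC)c(OC)c(OC)c3)sc3ccccc23)cc1`, which carries ethoxy in place of methyl on an aromatic carbon, para to a large group: ethoxy in place of methyl on an aromatic carbon. Within the data shown here, no measured step shows this exchange directly. Among the measured compounds shown here, the only step available is a 1.2-fold lower number from compound 1 to compound 2 (0.08 log units; within the scatter), which put (4-methylphenyl)amino in place of 4-methoxyphenyl and stayed within the scatter. It offers weak guidance, as it concerns a different change, and it gives no direction to carry forward. In this assay no shift beyond the scatter is therefore expected, and the estimated step is a 1.2-fold lower number from compound 2 to compound 3 (0.07 log units; within the scatter). With so little data the range must stay wide, since a single new group could still matter. For compound 3 the expected value is 3000 nM, with an estimated range from 400 nM to 9000 nM.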

Compound 3, half-maximal inhibitory concentration: 700 nM
Beside the measured number, compound 3's estimate is 4.3-fold (0.63 log units) above it; the range from low to high includes it.
By their numbers in this assay, from the lowest: compound 3; then compounds 2 and 1 (each within the scatter of the next).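

In this assay, ethoxy in place of methyl on an aromatic carbon, para to a large group, gives a 5.0-fold lower number from compound 2 to compound 3 (0.70 log units; beyond the scatter) and so produces a shift beyond the scatter, which the earlier pair of compounds did not show. Measured against the other earlier compound, the exchange of 4-methoxyphenyl for (4-ethoxyphenyl)amino gives a 6.0-fold lower number from compound 1 to compound 3 (0.78 log units; beyond the scatter) in the same direction, so compound 3 stands clearly apart from both, while those two remain within the scatter of each other. This position therefore responds to a small change, here from a group of 1 heavy atom to one of 3 heavy atoms that adds a hydrogen-bond acceptor, but no measurement shown accounts for the shift.

The compounds shown leave open whether the oxygen or the added carbons matter more, a question that ethyl, made of carbon alone, or methoxy at this same place could address. They also leave open how far the trend runs, for instance whether a longer propoxy chain or an amine at this position would continue it or reverse it.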